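Reshaping the Side Chain of Compound 2

A few compounds are considered here, and "the series" means these few. Any claim that something is new, unique, unknown or untested is made for them only; others in the source may bear on it.

In a functional assay for inhibition, with Rattus norvegicus as the target (on this read-out higher numbers stand for an effect only at larger amounts of compound and lower numbers for an effect already at smaller amounts), compound 2 `CCCC[C@H](CC1CCCCC1)NCc1ccc(C(=O)N[C@@H](CCSC)C(=O)O)c(-c2ccccc2C)c1` gives 4.3 nM and is the only one of the three measured compounds with an actual number. Compound 1 `CC[C@H](CC1CCCCC1)NCc1ccc(C(=O)N[C@@H](CCSC)C(=O)O)c(-c2ccccc2C)c1` reads > 1000 nM as a limit of the assay. Compound 3 `CSCC[C@H](NC(=O)c1ccc(CN(CCC2CCCCC2)C(=O)c2ccccc2)cc1-c1ccccc1C)C(=O)O` reads > 1000 nM as a limit too.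

Among the compounds with values here, the only measured step that bears on the new change is an at least 230-fold lower number from compound 1 to compound 2 (2.36 log units; beyond the scatter) and it is large, so this side chain can move the number a long way. Compound 4 `CSCC[C@H](NC(=O)c1ccc(CN[C@H](CSC(C)(C)C)CC2CCCCC2)cc1-c1ccccc1C)C(=O)O` has not been measured, and it differs through (tert-butyl)sulfanyl in place of propyl on a saturated chain carbon, two bonds along the chain from an amine nitrogen in that same chain, where butyl gives way to ((tert-butyl)sulfanyl)methyl. A long group therefore stays in place, so a fall to the limit is not the main expectation. Compound 2 at 4.3 nM remains the anchor. With a single step to go on, the expected change a 2.8-fold higher number from compound 2 to compound 4 (0.45 log units; beyond the scatter) is a modest one towards a higher number in this assay and remains uncertain. For compound 4 the estimated value is 12 nM with an expected range from 1.5 nM to 150 nM here.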

Compound 4, half-maximal effective concentration: 2.8 nM
Estimate against measurement, compound 4: 4.3-fold (0.63 log units) above; the measured number falls inside the stated range.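

In this assay, (tert-butyl)sulfanyl in place of propyl gives a 1.5-fold lower number from compound 2 to compound 4 (0.19 log units; within the scatter), so the two groups cannot be told apart on this saturated chain carbon, two bonds along the chain from an amine nitrogen. Compound 1, with methyl at that place, reads > 1000 nM, which is a limit of the assay. Methyl to (tert-butyl)sulfanyl gives an at least 350-fold lower number from compound 1 to compound 4 (2.55 log units; beyond the scatter), so a group containing sulfur restores the low number just as the all-carbon propyl does, and the chain at this position need not be purely carbon.

On these data alone, whether a hydroxyl group, a phenyl ring or a longer chain at this place would keep the number low stays open. The true size of the steps from compound 1 also stays unknown: the limit of > 1000 nM in this assay, at which 2 of the 4 values shown sit.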